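Swapping phenyl for thiophen-2-yl on the amide of compound 3

A few compounds are considered here, and "the series" means these few. Any claim that something is new, unique, unknown or untested is made for them only; others in the source may bear on it.

Compound 1 `CCCCCCCCCCCCCCCCCCNC(=O)[C@@H](N)[C@@H](C)O` gives 27400 nM in a functional assay on MCF7 cells (Homo sapiens) for cytotoxicity, read by MTT assay, with a stated time of 48 h; a higher number here means a weaker inhibitor, a lower number a stronger inhibitor.
Compound 2 `CCCCCCCCNC(=O)[C@@H](NC(=O)c1cccs1)[C@@H](C)O` gives 72500 nM in this assay.
Compound 3 `CCCCCCCCCCCCCCCCCCNC(=O)[C@@H](NC(=O)c1ccccc1)[C@@H](C)O` gives 31800 nM in this assay.

Among these three numbers compound 3 holds the second highest place. Its nearest neighbour is compound 1, and the step of a 1.2-fold higher number from compound 1 to compound 3 (0.06 log units; within the scatter) shows that adding the benzoyl group to the amine nitrogen left the number essentially unchanged. Compound 2, the furthest of the three, already carries the thiophene carbonyl group but on a much shorter chain, so its number cannot be read as a test of the aromatic ring alone.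

Compound 4 `CCCCCCCCCCCCCCCCCCNC(=O)[C@@H](NC(=O)c1cccs1)[C@@H](C)O` differs from compound 3 in a single place: thiophen-2-yl in place of phenyl on a carbonyl carbon. For the measured compounds named here, no measured pair isolates this exchange. Going by the values given here, the only directly comparable step, from compound 1 to compound 3, was within the scatter, which suggests that this part of the molecule does little to the read-out. The higher number of compound 2 leaves some room for a move upward. For compound 4 the expected step is a 1.2-fold higher number from compound 3 to compound 4 (0.08 log units; within the scatter), and the estimated value is 38000 nM, with a range from 15000 nM to 90000 nM.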

Compound 4, half-maximal inhibitory concentration: 25700 nM
Compound 4: middle estimate off by 1.5-fold (0.17 log units), on the high side, within the range that was stated.
By their numbers in this assay, from the lowest: compounds 4, 1 and 3 (each within the scatter of the next); then compound 2.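

In this assay, thiophen-2-yl in place of phenyl on the carbonyl carbon gives a 1.2-fold lower number from compound 3 to compound 4 (0.09 log units; within the scatter), so this first direct test of the exchange shows no change that can be told from the scatter. Placing (thiophen-2-yl)carbonyl on the amine nitrogen likewise gives a 1.1-fold lower number from compound 1 to compound 4 (0.03 log units; within the scatter), whereas decyl in place of hydrogen on the saturated chain, eight bonds along the chain from the amide-type nitrogen, gives a 2.8-fold lower number from compound 2 to compound 4 (0.45 log units; beyond the scatter), a modest step and the only one of the three beyond the scatter. No measurement shown here gives a reason for these steps.

As far as these compounds go, whether furan-2-yl on the same carbonyl carbon, or an amine or a carboxylic acid on the aromatic ring, would move the number remains open. So does the effect of a chain longer than the one in compound 4.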